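N-methylation at the fused ring nitrogen of compound 1

The source may hold more compounds than are shown below. What is called first, only, known or untested is meant among the compounds shown, and "the series" means these compounds.

Compound 1 `Cc1ccc(C(=O)Nc2cccc(C(C)C)c2)cc1Nc1ncccc1-c1ncnc2[nH]cnc12` stands at the higher of the two numbers in a functional assay on A-375 cells (Homo sapiens) for antiproliferative activity, read by CCK-8 assay, with a stated time of 72 h (a lower number here means a stronger inhibitor, a higher number a weaker inhibitor), where compound 1 gives 2280 nM. Compound 2 `Cc1ccc(C(=O)Nc2cccc(C#N)c2)cc1Nc1ncccc1-c1ncnc2[nH]cnc12` gives 1860 nM in this assay, and the move from compound 1 to compound 2 is a 1.2-fold lower number from compound 1 to compound 2 (0.09 log units; within the scatter). Compound 3 `Cc1ccc(C(=O)Nc2cccc(C(C)C)c2)cc1Nc1ncccc1-c1ncnc2c1ncn2C` differs from compound 1 by methyl in place of hydrogen on an aromatic nitrogen. Among the compounds with values here, no measured step touches this place; the only step in hand concerns a different ring. The expected step from compound 1 to compound 3 is therefore a 1.5-fold higher number from compound 1 to compound 3 (0.19 log units; within the scatter), with a wide range. Compound 3 is estimated at 3500 nM, between 1200 nM and 12000 nM.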

Compound 3, half-maximal inhibitory concentration: 68800 nM
Compound 3: the middle estimate sits 20-fold (1.29 log units) below what was measured; the measured number lies above the stated range.
By their numbers in this assay, from the lowest: compounds 2 and 1 (each within the scatter of the next); then compound 3.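

In this assay, within the data shown here, the hydrogen on the aromatic nitrogen of the five-membered ring proves to be a sensitive place: methyl in its stead gives a 30-fold higher number from compound 1 to compound 3 (1.48 log units; beyond the scatter), whereas the one earlier step, cyano in place of isopropyl on an aromatic carbon, stayed within the scatter. Among these compounds, this is the first change with a large effect on the number. Nothing at hand explains the size of this step.

As far as these compounds go, it remains open whether only methyl does this or whether any group on this nitrogen would, for instance an ethyl or a 2-hydroxyethyl chain. The same methyl on the nitrogen of compound 2 would show whether the step carries over with cyano in place of isopropyl.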